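Removing the side chain of compound 3

A few compounds are considered here, and "the series" means these few. Any claim that something is new, unique, unknown or untested is made for them only; others in the source may bear on it.

In a toxicity assay on HEK-293T cells (Homo sapiens) for cytotoxicity, read by MTT assay, with a stated time of 72 h (on this read-out higher numbers stand for weaker inhibition and lower numbers for stronger inhibition), compound 3 (`CN(C)CCCCn1c2c(c3ccccc31)C(=O)c1c[n+]([O-])c3ccccc3c1C2=O`) gives 520 nM. Compound 1 (`O=C1c2c[n+]([O-])c3ccccc3c2C(=O)c2c1c1ccccc1n2CCCCn1ccnc1`) gives 280 nM, and the step between these two is a 1.9-fold higher number from compound 1 to compound 3 (0.27 log units; within the scatter). Compound 2 (`O=C1c2c[n+]([O-])c3ccccc3c2C(=O)c2c1c1ccccc1n2Cc1cn(C[C@H](O)CO)nn1`) gives 8880 nM, and the step from it is a 17-fold lower number from compound 2 to compound 3 (1.23 log units; beyond the scatter). Compound 3 thus stands with compound 1, well apart from compound 2.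

The change to compound 4 (`O=C1c2c[n+]([O-])c3ccccc3c2C(=O)c2[nH]c3ccccc3c21`) is hydrogen in place of 4-(dimethylamino)butyl on an aromatic nitrogen, on an aromatic nitrogen of a five-membered aromatic ring. For the measured compounds named here, no measured compound carries hydrogen at this place, so no step speaks to the change directly. Only exchanges of one side chain for another are available. Of these, a 32-fold higher number from compound 1 to compound 2 (1.50 log units; beyond the scatter) shows that the group on this nitrogen can shift the number widely in this assay, whereas the exchange between compound 1 and compound 3 stays within the scatter. Replacing the side chain of compound 1 raised the number for compound 2 to 8880 nM, so a moderate move to a higher number is expected here, with little certainty about its direction. The estimated step is a 2.3-fold higher number from compound 3 to compound 4 (0.36 log units; beyond the scatter). For compound 4 the expected value is 1200 nM, with an estimated range from 250 nM to 6000 nM.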

Compound 4, half-maximal inhibitory concentration: 890 nM
Compound 4: middle estimate off by 1.3-fold (0.13 log units), on the high side, and the stated range covers the measured number.
By their numbers in this assay, from the lowest: compounds 1, 3 and 4 (each within the scatter of the next, the first and the last beyond it); then compound 2.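

In this assay, the aromatic nitrogen of the five-membered ring now carries hydrogen alone, and the loss of the 4-(dimethylamino)butyl stays within the scatter (a 1.7-fold higher number from compound 3 to compound 4 (0.23 log units; within the scatter)), so at this position that chain is not required for a number of this order. The same hydrogen compound lies modestly apart from the 4-(1H-imidazol-1-yl)butyl compound (a 3.2-fold higher number from compound 1 to compound 4 (0.50 log units; beyond the scatter)) and further from the compound bearing (1-(2,3-dihydroxypropyl)-1H-1,2,3-triazol-4-yl)methyl (a 10-fold lower number from compound 2 to compound 4 (1.00 log units; beyond the scatter)), which places the outlying number of compound 2 with that group and not with the shared core. No measurement at hand accounts for the size or direction of any of these steps.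

The compounds shown leave open whether the high number of compound 2 follows the triazole or the diol, which a triazole with a plain methyl in place of the 2,3-dihydroxypropyl would separate. They also leave open how a short methyl on this nitrogen, a primary amine or a carboxylic acid at the end of the butyl chain would compare with the hydrogen of compound 4.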